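Notes on an aryl exchange from compound 2

This account rests on a few compounds, and the source may have more. Where it says the series, first, only, none or still open, it means among the compounds named here.

Values so far in an ADME assay (liver) for metabolic stability, with Liver microsome (Homo sapiens) as the target, read by LC-MS, using microsomes, with a stated time of 30 min, tested at 4 uM (on this read-out higher numbers stand for a more stable compound and lower numbers for a less stable compound), for the series
- compound 1 `Cc1nc(N2CCN(C)CC2)c2nc(-c3ccccc3Cl)n(CCN3CCCC3=O)c2n1` gives 13% 
- compound 2 `Cc1nc(N2CCN(C)CC2)c2nc(-c3cccc(C(F)(F)F)c3)n(C3CCOCC3)c2n1` gives 19% 

Compound 2 at 19% lies within the scatter of compound 1 at 13% and the two cannot be separated. Compound 3 `Cc1nc(N2CCN(C)CC2)c2nc(-c3ccccc3C)n(C3CCOCC3)c2n1` carries 2-methylphenyl in place of 3-(trifluoromethyl)phenyl on an aromatic carbon and keeps the oxan-4-yl group. Within the data shown here, no two measured compounds differ in one place only, so this assay offers no direct precedent for this exchange. The expected change is a number 1 percentage points higher from compound 2 to compound 3 (within the scatter) and no step beyond the scatter is anticipated. Compound 3 is estimated at 20% with a range from 9% to 38% in this read-out.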

Compound 3, percent of the compound remaining: 18%
Estimate against measurement, compound 3: 2 percentage points above; low and high end bracket the measured number.
By their numbers in this assay, from the lowest: compounds 1, 3 and 2 (each within the scatter of the next).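

In this assay the series now has its first step in one place, a number 1 percentage points lower from compound 2 to compound 3 (within the scatter), at the aromatic carbon between two ring nitrogen atoms with the oxan-4-yl group kept. Exchanging 3-(trifluoromethyl)phenyl for 2-methylphenyl therefore does not separate the two compounds, even though all fluorine leaves the molecule. Nothing available explains this outcome.

Going by these compounds, whether a pyridyl ring, or a phenyl ring bearing an amine or a carboxylic acid, would give a step beyond the scatter at this position remains open. Also open, on these data alone, is whether this aryl exchange would read the same with a group other than oxan-4-yl.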